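Exchanging the Difluorophenyl for Trifluoromethylphenyl: Expected Exposure

The source may report more compounds than this note shows. Statements on the series, on what has been measured and on what is new or still open speak of the compounds shown alone.

Compound 1, `C/C=C(\c1ccccc1)c1ccc2nc(N)n(S(=O)(=O)C(C)C)c2c1`, gives 14300 nM.
Compound 2, `C#C/C=C(/c1ccc2nc(N)n(S(=O)(=O)C(C)C)c2c1)c1cc(F)ccc1F`, gives 23200 nM.
Compound 3, `C#C/C=C(\c1cc(F)cc(F)c1)c1ccc2nc(N)n(S(=O)(=O)C(C)C)c2c1`, gives 44800 nM.

These numbers come from an in vivo ADME assay on the whole organism (plasma) with Mus musculus as the target, at a dose of 100 mg/kg by the oral route; on this read-out higher numbers stand for higher exposure at the dose given and lower numbers for lower exposure. Compound 3 gives the highest of the three; the step of a 1.9-fold higher number from compound 2 to compound 3 (0.29 log units; within the scatter) lies within the scatter, while compound 1 sits further below, beyond the scatter. Compound 4, `C#C/C=C(\c1cccc(C(F)(F)F)c1)c1ccc2nc(N)n(S(=O)(=O)C(C)C)c2c1`, differs from compound 3 in one place: 3-(trifluoromethyl)phenyl in place of 3,5-difluorophenyl on a double-bonded chain carbon bound to an aromatic carbon and a double-bonded chain carbon. Among the measured compounds shown here, no measured step exchanges a difluorophenyl for a trifluoromethylphenyl; the only single-place step, a 1.9-fold higher number from compound 2 to compound 3 (0.29 log units; within the scatter), swapped one difluorophenyl for another and stayed within the scatter. Compound 4 is therefore expected to move little, with the estimated step of a 1.3-fold lower number from compound 3 to compound 4 (0.11 log units; within the scatter) staying within the scatter. Compound 4 is estimated at 35000 nM, with a range from 15000 nM to 80000 nM.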

Compound 4, maximal plasma concentration: 11300 nM
For compound 4 the middle estimate is 3.1-fold (0.49 log units) above the measured one; measured number below the stated range.
By their numbers in this assay, from the lowest: compounds 4, 1, 2 and 3 (each within the scatter of the next, the first and the last beyond it).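

Unlike the exchange of one difluorophenyl for another, this change on a double-bonded chain carbon goes beyond the scatter in this assay, with a 4.0-fold lower number from compound 3 to compound 4 (0.60 log units; beyond the scatter) and a 2.1-fold lower number from compound 2 to compound 4 (0.31 log units; beyond the scatter). The aryl group at this place therefore does matter, and 3-(trifluoromethyl)phenyl gives lower exposure than either difluorophenyl. No accompanying measurement bears on why the number falls. Still open, as far as these compounds go, is how a phenyl ring carrying a single fluorine, a chlorine or a methoxy group would compare, and whether a pyridine ring could take the place of the phenyl ring.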